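Swapping the halogenated phenyl ether ahead of compound 3

The source may hold more compounds than are shown below. What is called first, only, known or untested is meant among the compounds shown, and "the series" means these compounds.

Compound 1 `O=C(O)c1cncc(-c2ccc(N3CCC(Oc4ccccc4C(F)(F)F)CC3)nn2)c1`: 1300 nM
Compound 2 `O=C(O)c1cncc(-c2ccc(N3CCC(Oc4ccccc4I)CC3)nn2)c1`: 1000 nM

Of the compounds shown here, two have been measured in an assay on cells (Hepatocyte, strain Sprague-Dawley) for inhibition of acyl-CoA desaturase 1 (Rattus norvegicus), read by HPLC; a higher number here means a weaker inhibitor, a lower number a stronger inhibitor. Compound 1 gives 1300 nM, and compound 2 gives 1000 nM. Compound 2 has the lowest of the two numbers, but the step of a 1.3-fold lower number from compound 1 to compound 2 (0.11 log units; within the scatter) is within the scatter, so the two cannot be separated on this assay.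

Compound 3 `O=C(O)c1cncc(-c2ccc(N3CCC(Oc4cc(F)c(F)cc4Br)CC3)nn2)c1` differs from compound 2 by 2-bromo-4,5-difluorophenyl in place of 2-iodophenyl on an oxygen on a saturated carbon. Among the compounds with values here, the only measured step that bears on this position, the step of a 1.3-fold lower number from compound 1 to compound 2 (0.11 log units; within the scatter), shows that exchanging the group on that aromatic carbon changed little. Within the data shown here, no measured pair shows the effect of adding two fluorines to that ring, so nothing supports a shift beyond the scatter in either direction. Compound 3 is therefore expected to give a number close to that of compound 2, an estimated step of a 1.1-fold lower number from compound 2 to compound 3 (0.05 log units; within the scatter). For compound 3 the estimate in this assay is 900 nM, with a range from 400 nM to 2500 nM.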

Compound 3, half-maximal inhibitory concentration: 563 nM
Beside the measured number, compound 3's estimate is 1.6-fold (0.20 log units) above it; the measured number falls inside the stated range.
By their numbers in this assay, from the lowest: compounds 3, 2 and 1 (each within the scatter of the next, the first and the last beyond it).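

In this assay, replacing 2-iodophenyl with 2-bromo-4,5-difluorophenyl on the oxygen gives a 1.8-fold lower number from compound 2 to compound 3 (0.25 log units; within the scatter), so this change does not separate the two compounds. Within the data shown here, replacing 2-(trifluoromethyl)phenyl with the same group gives a 2.3-fold lower number from compound 1 to compound 3 (0.36 log units; beyond the scatter), which is the first step at this position to pass the scatter, although only modestly, and it shows that this position can tolerate a larger substituted phenyl without any loss. Nothing measured here accounts for either step.

The compounds shown do not separate the contribution of the bromine from that of the two fluorines, which a 2-bromophenyl group would begin to address. Also open, on these data alone, is what a chlorine or a methoxy group on this ring would do, and whether an amide could stand in place of the carboxylic acid.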